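Methoxy added on the benzylidene arm of compound 3

The compounds below may be only part of what the source reports. "The series", "measured", "known", "first", "only" and "open" are said of these compounds alone.

In a functional assay on A549 cells (Homo sapiens) for cytotoxicity, read by sulforhodamine B assay, with a stated time of 72 h (a lower number here means a stronger inhibitor, a higher number a weaker inhibitor), compound 3 `Cc1c(-c2csc(/N=C3\S/C(=C\c4ccccc4)C(=O)N3c3ccccc3)n2)c(=O)n(-c2ccccc2)n1C` returns only a limit, > 100000 nM. Compound 1 `CC(=O)c1nn(-c2ccc([N+](=O)[O-])cc2)/c(=N/c2nc(-c3c(C)n(C)n(-c4ccccc4)c3=O)cs2)s1` likewise returns a limit, > 100000 nM. Among the measured compounds shown here, compound 2 `CCOC(=O)c1nn(-c2ccc(OC)cc2)/c(=N/c2nc(-c3c(C)n(C)n(-c4ccccc4)c3=O)cs2)s1` is the one member with a number, 13100 nM. Compound 3 therefore stands together with compound 1 at the limit of > 100000 nM in this assay, at which 2 of the 3 values shown sit, and no number is known for it. Compound 4 `COc1ccc(/C=C2\S/C(=N\c3nc(-c4c(C)n(C)n(-c5ccccc5)c4=O)cs3)N(c3ccccc3)C2=O)cc1` differs from compound 3 by methoxy in place of hydrogen on an aromatic carbon. For the measured compounds named here, no step between measured compounds exists in this assay, so the size of this change cannot be read from the series, and a parent at the limit gives no direction beyond the scatter. Compound 4 is expected at 90000 nM, within 20000 nM to 400000 nM. The expected step is an at least 1.1-fold lower number from compound 3 to compound 4 (0.04 log units; that floor lies within the scatter), with a limit again the likeliest outcome.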

Compound 4, half-maximal inhibitory concentration: 9100 nM
Compound 4: middle estimate off by 9.9-fold (1.00 log units), on the high side, outside the stated range (below it).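

In this assay, the phenyl to 4-methoxyphenyl change on the benzylidene arm gives an at least 10-fold lower number from compound 3 to compound 4 (1.04 log units; beyond the scatter), the first step readable in this series. A single methoxy on an aromatic carbon, para to a large group, is enough to move this arm from a limit to a measured value. Compound 3 has only a limit, so the step sets a floor and its full size remains unknown: the limit of > 100000 nM in this assay, at which 2 of the 4 values shown sit.

As far as these compounds go, whether a hydroxy group, a fluorine or an amine at this place would give a similar step remains open. So does the effect of a methoxy elsewhere on this ring.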